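A few compounds are considered here, and "the series" means these few. Any claim that something is new, unique, unknown or untested is made for them only; others in the source may bear on it.

Measured so far:
compound 1 `CCCc1nnc(O)n2c(C)ncc12` gives > 48000 nM
compound 2 `C=CCSc1nncc2cnc(C)n12` gives 61000 nM

Both compounds were tested in a functional assay for inhibition, with Homo sapiens as the target; a lower number here means a stronger inhibitor, a higher number a weaker inhibitor. The value for compound 1, > 48000 nM, is a limit of the assay rather than a number. Compound 2 gives 61000 nM in this assay, a weak result, and it stands as the only number shown. The other value, that of compound 1, sits at the limit (the limit of > 48000 nM in this assay, at which 1 of the 2 values shown sits). Compound 3 `Cc1ncc2cnnc(O)n12` has not yet been measured in this assay. It differs from compound 2 in one place hydroxy in place of allylsulfanyl on an aromatic carbon. Among the compounds with values here, no measured pair shows a change of this kind, so the expectation rests on the weak starting point of compound 2 alone. The expected step of a 1.3-fold higher number from compound 2 to compound 3 (0.12 log units; within the scatter) in this assay is either none beyond the scatter or a shift toward weaker inhibition. Compound 3 is therefore estimated at 80000 nM, within 20000 nM to 300000 nM in this assay, with a real chance that only a limit is reported.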

Compound 3, half-maximal inhibitory concentration: > 48000 nM
Compound 3: no number, only a limit (the forecaster's own chance of this, stated with the estimate: 60%); the middle value does not contradict the limit.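

In this assay compound 3 gives > 48000 nM, which is a limit of the assay and not a number. The steps to compound 3 from compound 1 and compound 2 therefore cannot be read: the limit of > 48000 nM in this assay, at which 2 of the 3 values shown sit.

The compounds shown leave open whether hydroxy in place of allylsulfanyl, or hydrogen in place of propyl, changes inhibition at all.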